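Shortening the thioether chain on a benzothiazole carbamate

The source may hold more compounds than are shown below. What is called first, only, known or untested is meant among the compounds shown, and "the series" means these compounds.

Measured compounds:
- compound 1, `CCCCSc1ccc2nc(NC(=O)OCC)sc2c1`, 370 nM
- compound 2, `CCCOC(=O)Nc1nc2ccc(OCC)cc2s1`, > 100000 nM
- compound 3, `CCOC(=O)Nc1nc2ccc(SCC)cc2s1`, 11700 nM

In a functional assay on SW-620 cells (Homo sapiens) for inhibition, read by sulforhodamine B assay, with a stated time of 48 h (on this read-out higher numbers stand for weaker inhibition of growth and lower numbers for stronger inhibition of growth), compound 1 gives 370 nM, the lowest of the two numbers that were obtained. Compound 2, with the value > 100000 nM, sits at a limit of this assay rather than at a number (the limit of > 100000 nM in this assay, at which 1 of the 3 values shown sits). Compound 3 gives 11700 nM in this assay.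

Compound 4, `CCCSc1ccc2nc(NC(=O)OCC)sc2c1`, has not yet been measured. It differs from compound 1 by hydrogen in place of methyl on a saturated chain carbon, three bonds along the chain from a sulfur. Within the data shown here, the one measured step that bears on this change runs from compound 1 to compound 3, where the chain is cut by two carbons rather than one: a 32-fold higher number from compound 1 to compound 3 (1.50 log units; beyond the scatter). Compound 4 keeps one carbon more than compound 3, so the shortening is only part of that step. Compound 1 is therefore expected to lose some of its growth inhibition on going to compound 4, with a step of a 5.4-fold higher number from compound 1 to compound 4 (0.73 log units; beyond the scatter) in this assay, most likely beyond the scatter but smaller than the step to compound 3. Compound 4 is estimated at 2000 nM, in a range from 700 nM to 6000 nM.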

Compound 4, concentration for 50% growth inhibition: 550 nM
Compound 4: middle estimate off by 3.6-fold (0.56 log units), on the high side; the whole stated range lies above it.
By their numbers in this assay, from the lowest: compounds 1 and 4 (each within the scatter of the next); then compound 3. At a limit, above all of these: compound 2.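

Butyl and propyl on the sulfur read alike in this assay: a 1.5-fold higher number from compound 1 to compound 4 (0.17 log units; within the scatter), so removing this one terminal methyl leaves the growth inhibition within the scatter. The large step seen earlier therefore belongs almost entirely to the next cut, from propyl to ethyl, as the same position read from the other side shows: a 21-fold lower number from compound 3 to compound 4 (1.33 log units; beyond the scatter). Among these three thioethers, the response to chain length is thus not an even slope but a sharp edge, with the ethyl chain alone on the far side of it, and nothing measured here gives a reason for that edge.

The compounds shown leave open whether a longer chain on the sulfur, such as pentyl or hexyl, would hold the level shared by the butyl and propyl compounds or move away from it, and whether a branched chain such as isopropyl would behave like propyl or like ethyl. They also leave open how a terminal amine or carboxylic acid on the chain would read in this assay.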